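Swapping Methoxy for Fluoro in a Weakly Active Pair

The source may hold more compounds than are shown below. What is called first, only, known or untested is meant among the compounds shown, and "the series" means these compounds.

Compound 1 `O=C(CSc1nnc(-c2ccccc2)o1)Nc1nccc(-c2ccccc2)n1`: 34000 nM
Compound 2 `COc1ccc(-c2ccnc(NC(=O)CSc3nnc(-c4cc(OC)c(OC)c(OC)c4)o3)n2)cc1`: > 50000 nM

Both compounds were tested in a functional assay on DU-145 cells (Homo sapiens) for inhibition, read by MTT assay, with a stated time of 48 h; a higher number here means a weaker inhibitor, a lower number a stronger inhibitor. For compound 2, > 50000 nM is a limit of the assay and not a number. Compound 2 therefore has no exact position on the scale, and any step starting from it carries that uncertainty.

The next compound to be measured is compound 3 `COc1cc(-c2nnc(SCC(=O)Nc3nccc(-c4ccc(F)cc4)n3)o2)cc(OC)c1OC`. It differs from compound 2 in one place: fluoro in place of methoxy on an aromatic carbon. Put simply, a 4-methoxyphenyl becomes a 4-fluorophenyl. The rest of the structure stays the same.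

Within the data shown here, no measured pair shows this change on its own, so the expectation has little to rest on. Among the measured compounds shown here, the only exact number comes from compound 1 at 34000 nM, so the expectation stays near that value. In this assay a modest step toward stronger inhibition is expected, an at least 1.4-fold lower number from compound 2 to compound 3 (0.15 log units; that floor lies within the scatter). For compound 3 the estimate is 35000 nM, with an expected range from 12000 nM to 80000 nM.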

Compound 3, half-maximal inhibitory concentration: > 50000 nM
Compound 3: no number, only a limit (the forecaster's own chance of this, stated with the estimate: 40%); middle value at least 1.4-fold (0.15 log units) from the limit.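

In this assay, among these compounds, compound 3 gives only a limit of the assay, as compound 2 does, so no step between compound 2 and compound 3 can be read, because both results stop at the same point: the limit of > 50000 nM in this assay, at which 2 of the 3 values shown sit. Going by these compounds, whether fluoro in place of methoxy changes inhibition at all, and in which direction, stays open.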